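This account rests on a few compounds, and the source may have more. Where it says the series, first, only, none or still open, it means among the compounds named here.

Notes on the series around compound 1 `O=C1C(=Cc2ccc(Cl)cc2)C(=O)N(c2ccc(Cl)cc2)N1c1ccc(Cl)cc1`, read in a functional assay on SMMC-7721 cells (Homo sapiens) for cytotoxicity, read by MTT assay, with a stated time of 72 h; on this read-out lower numbers stand for stronger inhibition and higher numbers for weaker inhibition. Compound 1 gives 30900 nM, and compound 2 `COc1cccc(C=C2C(=O)N(c3ccc(Cl)cc3)N(c3ccc(Cl)cc3)C2=O)c1O` gives 64900 nM. Compound 3 `COc1ccc(C=C2C(=O)N(c3ccc(Cl)cc3)N(c3ccc(Cl)cc3)C2=O)cc1` is reported only as a limit, > 128000 nM, so it has no number of its own: the limit of > 128000 nM in this assay, at which 1 of the 3 values shown sits.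

Compound 4 `COc1ccc(C=C2C(=O)N(c3ccc(Cl)cc3)N(c3ccc(Cl)cc3)C2=O)cc1OC` differs from compound 3 by one change: methoxy in place of hydrogen on an aromatic carbon. This is methoxy in place of hydrogen on an aromatic carbon, turning 4-methoxyphenyl into 3,4-dimethoxyphenyl.

Among the compounds with values here, no measured step makes this exact change. The nearest evidence is on the same aryl position: methoxy in place of chloro gave an at least 4.1-fold higher number from compound 1 to compound 3 (0.61 log units; beyond the scatter), and the 2-hydroxy-3-methoxyphenyl change gave a 2.1-fold higher number from compound 1 to compound 2 (0.32 log units; beyond the scatter). The step of an at least 1.9-fold higher number from compound 2 to compound 3 (0.29 log units; that floor lies within the scatter) is only a floor within the scatter. Both methoxy-bearing measured compounds therefore sit on the weak side of compound 1, and a further methoxy is expected to leave the series there.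

The expected step is an at least 1.4-fold lower number from compound 3 to compound 4 (0.15 log units; that floor lies within the scatter), with none expected beyond the scatter. For compound 4 the estimated value is 90000 nM, within an expected range of 40000 nM to 180000 nM.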

Compound 4, half-maximal inhibitory concentration: > 128000 nM
Compound 4: no number, only a limit (the forecaster's own chance of this, stated with the estimate: 45%); middle value at least 1.4-fold (0.15 log units) away from the limit.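

Adding methoxy to give 3,4-dimethoxyphenyl yields no number in this assay: compound 4 is also reported only as a limit, like compound 3, so the step between them cannot be read. Within the data shown here, the one step that is beyond the scatter is an at least 4.1-fold higher number from compound 1 to compound 4 (0.61 log units; beyond the scatter), which extends the gap from the chloro compound to a second methoxy-bearing compound, while an at least 1.9-fold higher number from compound 2 to compound 4 (0.29 log units; that floor lies within the scatter) is only a floor and sets no order against the 2-hydroxy-3-methoxyphenyl compound. Two compounds now rest at the ceiling of the read-out: the limit of > 128000 nM in this assay, at which 2 of the 4 values shown sit.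

Going by these compounds, whether the added methoxy changes activity at all stays open, as neither limit gives a value to compare. Also open, on these data alone, is whether an amine or a carboxylic acid in place of the methoxy on this aromatic carbon would return a readable number.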